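Replacing hydroxy in compound 3: working notes

A few compounds are considered here, and "the series" means these few. Any claim that something is new, unique, unknown or untested is made for them only; others in the source may bear on it.

Measured in a functional assay on HUVEC cells (Homo sapiens) for antiproliferative activity; a lower number here means a stronger inhibitor, a higher number a weaker inhibitor:
- compound 1 `CC(C)c1c(-c2nnc(N(C)C)o2)cn2ncnc(Nc3cc(C(=O)NC4CC4)c(F)cc3F)c12`: "not determined" (no result reported)
- compound 2 `CC(C)Nc1nnc(-c2cn3ncnc(Nc4cc(C(=O)NC5CC5)c(F)cc4F)c3c2C(C)C)o1`: "not determined" (no result reported)
- compound 3 `CC(C)c1c(-c2nnc(NCCO)o2)cn2ncnc(Nc3cc(C(=O)NC4CC4)c(F)cc3F)c12`: 140 nM

Within the data shown here, compound 3 holds the only number, so it has no rank, and neither compound 1 nor compound 2 offers a comparison. Compound 4 `CNCCCNc1nnc(-c2cn3ncnc(Nc4cc(C(=O)NC5CC5)c(F)cc4F)c3c2C(C)C)o1` carries (methylamino)methyl in place of hydroxy on a saturated chain carbon, two bonds along the chain from a nitrogen on an aromatic ring. Among the measured compounds shown here, no measured step calibrates this change, so only a slight gain in this assay, hardly beyond the scatter, is expected. The expected change is a 1.4-fold lower number from compound 3 to compound 4 (0.15 log units; within the scatter). For compound 4 the estimate is 100 nM, with an expected range of 30 nM to 350 nM.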

Compound 4, half-maximal inhibitory concentration: 62 nM
The estimate for compound 4 lay 1.6-fold (0.21 log units) above the measured number, within the range that was stated.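

In this assay, among these compounds, the change gives the first readable step at this position: a 2.3-fold lower number from compound 3 to compound 4 (0.35 log units; beyond the scatter). On this saturated chain carbon, hydroxy can therefore give way to (methylamino)methyl with the number falling rather than rising, and the step lies beyond the scatter. Nothing available bears on the reason for this fall.

Among the compounds shown here, the single step joins a longer chain to a change from hydroxy to an amine, so the two remain unseparated. A 3-hydroxypropyl chain or a primary 3-aminopropyl chain on the same nitrogen would help to tell them apart.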